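Swapping the thiophene for a bromophenyl ring

The source may report more compounds than this note shows. Statements on the series, on what has been measured and on what is new or still open speak of the compounds shown alone.

In a functional assay on KM12 cells (Homo sapiens) for inhibition, read by sulforhodamine B assay, with a stated time of 48 h, tested at 10 uM (a higher number here means more inhibition at the concentration tested (going by the name of the read-out), a lower number less inhibition), the three measured compounds share one core and differ in a single aromatic group attached to it. Compound 1 `COc1ccc(-c2cn3ccnc3c(-c3ccc4ncn(C5CCCCC5)c4c3)n2)cc1` carries a 4-methoxyphenyl and gives 83.2%. Compound 2 `c1ccc2c(-c3cn4ccnc4c(-c4ccc5ncn(C6CCCCC6)c5c4)n3)cccc2c1` carries a naphthalen-1-yl and gives 11.1%. Compound 3 `c1cn2cc(-c3ccsc3)nc(-c3ccc4ncn(C5CCCCC5)c4c3)c2n1` carries a thiophen-3-yl and gives 15.4%. Compound 3 therefore stands second highest of the three, yet the step of a number 4.3 percentage points higher from compound 2 to compound 3 (within the scatter) is within the scatter, while the step of a number 67.8 percentage points lower from compound 1 to compound 3 (beyond the scatter) is large, as is a number 72.1 percentage points lower from compound 1 to compound 2 (beyond the scatter).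

Compound 4 `Brc1ccc(-c2cn3ccnc3c(-c3ccc4ncn(C5CCCCC5)c4c3)n2)cc1` is not yet measured. Its change from compound 3 is 4-bromophenyl in place of thiophen-3-yl on an aromatic carbon. Among the compounds with values here, no measured step involves a 4-bromophenyl, so direct guidance is missing. Within the data shown here, the only measured compound whose group is one six-membered aromatic ring of carbon only is compound 1, which gives 83.2%, and both measured replacements of that group lowered the number by a large amount. Among the measured compounds shown here, a bromine in place of a methoxy group has no measured precedent here.

Compound 4 is therefore expected to give 55%, with a range of 15% to 90%, which means an estimated step of a number 39.6 percentage points higher from compound 3 to compound 4 (beyond the scatter), upward but very uncertain.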

Compound 4, a percentage reported as inhibition, at one concentration (the size of the read-out at that concentration, not a potency): 23.3%
Beside the measured number, compound 4's estimate is 31.7 percentage points above it; measured number inside the range.
By their numbers in this assay, from the lowest: compounds 2, 3 and 4 (each within the scatter of the next, the first and the last beyond it); then compound 1.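

The 4-bromophenyl shows that a six-membered aromatic ring of carbon only is not enough at this position on the shared core: with bromo in place of methoxy, a number 59.9 percentage points lower from compound 1 to compound 4 (beyond the scatter) in this assay, so the group carried on that ring matters as well as the ring itself. The low numbers now extend to a compound with the same ring as compound 1, and the ring swap from thiophen-3-yl gives only a number 7.9 percentage points higher from compound 3 to compound 4 (within the scatter), while the swap from naphthalen-1-yl gives a modest a number 12.2 percentage points higher from compound 2 to compound 4 (beyond the scatter). Among the four compounds, only compound 1 stands far from the rest, and nothing shown explains the large gap between its methoxy and the bromo of compound 4.

On these data alone, it remains open whether the high number is specific to methoxy or would also appear with a hydroxy group, an amine or a longer chain such as ethoxy in its place. As far as these compounds go, each number is also a reading at one concentration, so how these gaps would translate into differences in potency remains open.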